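The compounds below may be only part of what the source reports. "The series", "measured", "known", "first", "only" and "open" are said of these compounds alone.

Compound 2, `CN(C)CCCN1CCN(CC(=O)Nc2ccc(-c3nc4ccccc4o3)cc2)CC1`, gives 16700 nM in an ADME assay on NIH3T3 cells (Mus musculus) for cytotoxicity, read by MTT assay, with a stated time of 24 h; a higher number here means a weaker inhibitor, a lower number a stronger inhibitor. Its only measured companion, compound 1, `Cc1ccc2oc(-c3ccc(NC(=O)CN4CCN(CCCN(C)C)CC4)cc3)nc2c1`, gives 26400 nM, and the two numbers lie within the scatter of each other. For the measured compounds named here, the one measured step, a 1.6-fold lower number from compound 1 to compound 2 (0.20 log units; within the scatter), is hydrogen in place of methyl on an aromatic carbon of the fused ring system of the shared core. Compound 3, `CN(C)CCCN1CCN(CC(=O)Nc2ccc(-c3nc4cc(F)ccc4o3)cc2)CC1`, has not yet been measured. It differs from compound 2 by fluoro in place of hydrogen on an aromatic carbon, placed on an aromatic carbon of a six-membered aromatic ring of carbon only, part of a fused system of two rings, so that 1,3-benzoxazol-2-yl becomes 5-fluoro-1,3-benzoxazol-2-yl. Going by the values given here, the only step that bears on this, a change of one substituent on the same fused ring, stayed within the scatter, so no step beyond the scatter is expected in this assay in either direction. Compound 3 is therefore expected to give about 17000 nM, between 8000 nM and 36000 nM. The expected step is a 1.0-fold higher number from compound 2 to compound 3 (0.01 log units; within the scatter), within the scatter.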

Compound 3, half-maximal inhibitory concentration: 21900 nM
Beside the measured number, compound 3's estimate is 1.3-fold (0.11 log units) below it, within the range that was stated.
By their numbers in this assay, from the lowest: compounds 2, 3 and 1 (each within the scatter of the next).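

In this assay fluoro on this aromatic carbon, turning 1,3-benzoxazol-2-yl into 5-fluoro-1,3-benzoxazol-2-yl, gives a 1.3-fold higher number from compound 2 to compound 3 (0.12 log units; within the scatter) and so adds a second substituent that leaves the number within the scatter of the unsubstituted compound. The direct exchange of the two substituents, a 1.2-fold lower number from compound 1 to compound 3 (0.08 log units; within the scatter) as well, stays within the scatter too, so hydrogen, methyl and fluoro cannot be told apart at this position in this assay. No measured evidence is available to account for this flat result.

The compounds shown leave open whether an amine, a carboxylic acid or a methoxy group on this same carbon would produce a step beyond the scatter. They also leave open whether fluoro on another carbon of this ring would do so.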